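Cyano for trifluoromethyl on the sulfonyl aryl ring

The compounds below may be only part of what the source reports. "The series", "measured", "known", "first", "only" and "open" are said of these compounds alone.

Two members of the series have numbers in a functional assay on HepG2 cells (Homo sapiens) for cytotoxicity, read by MTT assay, with a stated time of 24 h; on this read-out lower numbers stand for stronger inhibition and higher numbers for weaker inhibition. Compound 1 `O=C1/C(=C/c2ccccc2F)CN(S(=O)(=O)c2ccc(O[N+](=O)[O-])cc2)C/C1=C\c1ccccc1F` gives 16500 nM in this assay. Compound 2 `O=C1/C(=C/c2cccc(F)c2)CN(S(=O)(=O)c2ccc(C(F)(F)F)cc2)C/C1=C\c1cccc(F)c1` gives 2400 nM, the lower of the two numbers; the two structures differ in more than one place, so the gap between them is not traced to a single change. Compound 3 `N#Cc1ccc(S(=O)(=O)N2C/C(=C\c3cccc(F)c3)C(=O)/C(=C/c3cccc(F)c3)C2)cc1` is not yet measured. It differs from compound 2 by cyano in place of trifluoromethyl on an aromatic carbon. Among the compounds with values here, no measured pair shows this exchange, so there is no step to lean on. The expectation for compound 3 in this assay is a step from compound 2 of a 1.3-fold higher number from compound 2 to compound 3 (0.12 log units; within the scatter), not beyond the scatter in either direction. Compound 3 is therefore estimated at 3200 nM in this assay, with a range of 1200 nM to 8500 nM.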

Compound 3, half-maximal inhibitory concentration: 2600 nM
For compound 3 the middle estimate is 1.2-fold (0.09 log units) above the measured one, and the stated range covers the measured number.
By their numbers in this assay, from the lowest: compounds 2 and 3 (each within the scatter of the next); then compound 1.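

Within the data shown here, on the sulfonyl aryl ring, the exchange of 4-(trifluoromethyl)phenyl for 4-cyanophenyl gives in this assay a 1.1-fold higher number from compound 2 to compound 3 (0.03 log units; within the scatter) and is the first single-place step. On this one pair, the position accepts cyano in place of trifluoromethyl with the two numbers lying within the scatter of each other, whereas compound 1 differs from both in more than one place and could not show this. No available measurement bears on why the two numbers agree.

As far as these compounds go, whether an amine, a carboxylic acid or a methoxy group on this same aromatic carbon would also stay within the scatter of compound 2 remains open. Also open, from the compounds shown here alone, is whether the agreement between trifluoromethyl and cyano would hold with the fluorine arrangement of compound 1.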